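Aryl Variation at the Saturated Ring Carbon

A few compounds are considered here, and "the series" means these few. Any claim that something is new, unique, unknown or untested is made for them only; others in the source may bear on it.

For the measured compounds named here, compound 2 `COc1cc(C2=NN(C(C)=O)C(c3ccc(F)cc3)O2)cc(OC)c1OC` sits at the bottom of the two numbers measured so far: in a functional assay on BGC-823 cells (Homo sapiens) for antiproliferative activity, read by MTT assay, tested at 5 uM (a higher number here means a stronger effect of the compound at the concentration tested, a lower number a weaker effect), compound 2 gives 13.3%, while compound 1 `COc1cc(C2=NN(C(C)=O)C(c3ccccc3C(F)(F)F)O2)cc(OC)c1OC` gives 34.8%. Going by the values given here, the only measured step, a number 21.5 percentage points lower from compound 1 to compound 2 (beyond the scatter), runs downhill and shows that exchanging the group on the saturated ring carbon shifts the read-out by a modest but real amount.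

Compound 3 `COc1cc(C2=NN(C(C)=O)C(c3ccc(Cl)c(Cl)c3)O2)cc(OC)c1OC` has not been measured. It differs from compound 2 as follows: 3,4-dichlorophenyl in place of 4-fluorophenyl on a saturated ring carbon. The step from compound 1 to compound 2 is the one that bears on this change: it also swaps the group on the saturated ring carbon. Its direction cannot be carried over, as 3,4-dichlorophenyl appears in neither measured compound, so a step of similar size in either direction remains possible and a small rise is taken as the middle case. For compound 3 the expected step is a number 10.7 percentage points higher from compound 2 to compound 3 (beyond the scatter), giving an estimate of 24% with a range from 8% to 45%.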

Compound 3, a percentage reported as inhibition, at one concentration (the size of the read-out at that concentration, not a potency): 3.1%
Compound 3: the middle estimate sits 20.9 percentage points above what was measured; measured number below the stated range.
By their numbers in this assay, from the lowest: compound 3; then compound 2; then compound 1.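

The exchange at the saturated ring carbon moves the read-out a second time in this assay, with a number 10.2 percentage points lower from compound 2 to compound 3 (beyond the scatter), so the sensitivity of this position no longer rests on a single pair. Across the three aryl groups the spread widens to a number 31.7 percentage points lower from compound 1 to compound 3 (beyond the scatter), and compound 3, with 3,4-dichlorophenyl, now stands lowest of the series, its steps to both other compounds lying beyond the scatter. Nothing available explains why the three aryl groups rank in this order, so the ranking stands as an observation only.

Going by these compounds, the three compounds carry only substituted phenyl groups at this carbon, so it remains open how the read-out responds to an unsubstituted phenyl, a phenyl bearing an amine or a carboxylic acid, or a longer alkyl chain in place of the aryl ring. Three aryl groups also cannot separate the placement of a substituent on the ring from its identity, and whether 2-(trifluoromethyl)phenyl marks the top of what this position allows is still undecided.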